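Removing a methoxy group: cytotoxicity of three diarylpropanoids

The source may report more compounds than this note shows. Statements on the series, on what has been measured and on what is new or still open speak of the compounds shown alone.

Measured compounds:
- compound 1, `COc1ccc(CCCc2ccc(OC)c(OC)c2OC)c(O)c1`: 84.5%
- compound 2, `COc1ccc(C(=O)CCc2ccc(OC)c(OC)c2)c(O)c1`: 75.2%
- compound 3, `COc1ccc(CCC(=O)c2ccc(OC)cc2O)cc1`: 92.3%

The three compounds were examined in an ADME assay on RAW264.7 cells (Mus musculus) for cytotoxicity, read by MTT assay, with a stated time of 24 h, tested at 5 ug/mL; on this read-out lower numbers stand for a stronger effect and higher numbers for a weaker effect at the one concentration tested. Compound 1 gives 84.5%, compound 2 gives 75.2% and compound 3 gives 92.3%. Compound 1 and compound 3 lie within the scatter of each other, as do compound 1 and compound 2. The difference between the cores of compound 1 and compound 2 is not broken down here.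

One change is made twice. From compound 2 to compound 3 it is hydrogen in place of methoxy on an aromatic carbon, and in this assay it gave a number 17.1 percentage points higher from compound 2 to compound 3 (beyond the scatter). From compound 1 to the unmeasured compound 4, `COc1ccc(CCCc2cccc(OC)c2OC)c(O)c1`, the change is hydrogen in place of methoxy on an aromatic carbon. It is the same kind of change, though its surroundings differ: in compound 1 the carbon is para to a large group, whereas in compound 2 it is meta to a large group.

Resting on the step from compound 2 to compound 3, compound 4 is expected to give a number 7.5 percentage points higher from compound 1 to compound 4 (within the scatter) in this assay, with the ceiling of the read-out limiting the rise. Compound 4 is thus estimated at 92%, between 78% and 102%.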

Compound 4, a percentage reported as activity, at one concentration (the size of the read-out at that concentration, not a potency): 95.2%
Compound 4: middle estimate off by 3.2 percentage points, on the low side, within the range that was stated.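

In this assay, replacing a methoxy group with hydrogen on the core of compound 1 gave a number 10.7 percentage points higher from compound 1 to compound 4 (beyond the scatter), so the step seen on the other core also appears here. Among the compounds shown here, the two steps point the same way and do not differ in size beyond what repeated measurements would allow: the same change on two cores in this assay, a number 17.1 percentage points higher (beyond the scatter) from compound 2 to compound 3 and a number 10.7 percentage points higher (beyond the scatter) from compound 1 to compound 4, 6.4 percentage points apart, within the scatter of two such steps This agreement rests on only two cores and a single concentration, so it does not show that the change would carry over to every core, nor does it explain why the number rises.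

The compounds shown leave open whether an amine, a carboxylic acid or a fluorine in place of the methoxy group would act as hydrogen does. They also do not settle how the same change would behave on a core with a longer chain linking the two aromatic rings.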